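A few compounds are considered here, and "the series" means these few. Any claim that something is new, unique, unknown or untested is made for them only; others in the source may bear on it.

Of the compounds shown here, three have so far been measured in a functional assay on MDA-MB-435 cells (Homo sapiens) for cytotoxicity, read by sulforhodamine B assay, with a stated time of 48 h; a lower number here means that less compound is tolerated, a higher number that more compound is tolerated. Compound 1 `ClCc1cccc(Cn2cnc3ncnc(Cl)c32)c1` gives 39800 nM in this assay. Compound 2 `ClCc1ccccc1Cn1cnc2ncnc(Cl)c21` is built from the same atoms joined differently; the difference between the two cores is not broken down here. In this assay compound 2 gives 7580 nM. Compound 3 `ClCc1cccc(Cn2cnc3nc(Cl)nc(Cl)c32)c1` differs from compound 1 by chloro in place of hydrogen on an aromatic carbon, and in this assay compound 3 gives 5240 nM. That change made a 7.6-fold lower number from compound 1 to compound 3 (0.88 log units; beyond the scatter). The values of compound 2 and compound 3 lie within the scatter of each other, whereas compound 2 sits clearly lower than compound 1.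

Compound 4 `ClCc1ccccc1Cn1cnc2nc(Cl)nc(Cl)c21` has not yet been measured. It differs from compound 2 by chloro in place of hydrogen on an aromatic carbon, the same change, at the same place, that separates compound 3 from compound 1. If that change carries over, compound 4 is expected to show a 5.1-fold lower number from compound 2 to compound 4 (0.70 log units; beyond the scatter), an expectation resting on the single earlier step, a 7.6-fold lower number from compound 1 to compound 3 (0.88 log units; beyond the scatter). The estimate for compound 4 in this assay is 1500 nM, with an expected range from 500 nM to 5000 nM.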

Compound 4, concentration lethal to 50% of the cells: 58900 nM
Beside the measured number, compound 4's estimate is 39-fold (1.59 log units) below it, outside the stated range (above it).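

In this assay, chloro in place of hydrogen on an aromatic carbon, here between two ring nitrogen atoms, gives a 7.8-fold higher number from compound 2 to compound 4 (0.89 log units; beyond the scatter). Set beside the earlier step, the same change at the same place does not carry over from one core to the other; it lowers the number on the core of compound 1 and raises it on the core of compound 2: the same change on two cores in this assay, a 7.6-fold lower number (0.88 log units; beyond the scatter) from compound 1 to compound 3 and a 7.8-fold higher number (0.89 log units; beyond the scatter) from compound 2 to compound 4, 59-fold (1.77 log units) apart, beyond the scatter of two such steps. This shows that, for these two pairs, neither the size nor the direction of the step on one core could be taken over to the other, but it does not show what in the two cores, built from the same atoms joined differently, lies behind the reversal, and two pairs give no rule for any further core.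

From the compounds shown here alone, it remains open whether an amine or a methoxy group in place of this chloro would follow the pattern of either core. Going by these compounds, it also remains open how a third arrangement of the same atoms would respond to the chloro.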